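The source may report more compounds than this note shows. Statements on the series, on what has been measured and on what is new or still open speak of the compounds shown alone.

Compound 1 `NC1CCC(Nc2nc(NCc3ccc(-c4ccco4)cc3)c3ncn(C4CCCC4)c3n2)CC1`: 71 nM
Compound 2 `NC1CCC(Nc2nc(NCc3ccc(-c4cccs4)nc3)c3ncn(C4CCCC4)c3n2)CC1`: 40 nM

Both values come from a functional assay on HeLa cells (Homo sapiens) for inhibition, with a stated time of 72 h; a lower number here means a stronger inhibitor, a higher number a weaker inhibitor. Compound 2, at 40 nM, lies within the scatter of compound 1, so the two cannot be separated. Compound 3 `NC1CCC(Nc2nc(NCc3cc(Cl)ccc3O)c3ncn(C4CCCC4)c3n2)CC1` has 5-chloro-2-hydroxyphenyl in place of 6-(thiophen-2-yl)pyridin-3-yl on a saturated chain carbon bound to a nitrogen on an aromatic ring. Going by the values given here, the only measured step, a 1.8-fold lower number from compound 1 to compound 2 (0.25 log units; within the scatter), exchanges one pair of linked rings for another, and no measured compound has a single ring there. It therefore guides this change only weakly. In this assay, the expected change, tentatively toward a weaker inhibitor, is a 6.3-fold higher number from compound 2 to compound 3 (0.80 log units; beyond the scatter). For compound 3 the estimated value is 250 nM, with an expected range of 50 nM to 1200 nM.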

Compound 3, half-maximal inhibitory concentration: 750 nM
The estimate for compound 3 lay 3.0-fold (0.48 log units) below the measured number, and the stated range covers the measured number.
By their numbers in this assay, from the lowest: compounds 2 and 1 (each within the scatter of the next); then compound 3.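

In this assay, going by these compounds alone, the step of a 19-fold higher number from compound 2 to compound 3 (1.27 log units; beyond the scatter) and the step of an 11-fold higher number from compound 1 to compound 3 (1.02 log units; beyond the scatter) are the first here beyond the scatter, and both are large. They show that this position, on a saturated chain carbon bound to a nitrogen on an aromatic ring, does not accept every aryl group equally: 5-chloro-2-hydroxyphenyl gives a weaker inhibitor than either linked-ring group. No evidence on hand explains this difference.

The compounds shown leave open whether the single ring, the chlorine or the hydroxyl goes with the higher number, as all three arrive together. An unsubstituted phenyl, or a phenyl carrying an amine, would help to separate them.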